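This account rests on a few compounds, and the source may have more. Where it says the series, first, only, none or still open, it means among the compounds named here.

Measured compounds:

- Compound 1, `C=C[C@@](C)(/C=C/c1ccc(Nc2ccc(F)c(F)c2)cc1)CCC=C(C)C`. In a functional assay on Raji cells (Homo sapiens) for cytotoxicity, with a stated time of 72 h (on this read-out lower numbers stand for an effect already at smaller amounts and higher numbers for an effect only at larger amounts of compound), compound 1 gives > 26000 nM, which is a limit of the assay and not a number.
- Compound 2, `C=C[C@@](C)(/C=C/c1ccc(Nc2cc(F)c(F)cc2F)cc1)CCC=C(C)C`. In this assay compound 2 gives > 26000 nM, again a limit rather than a number.
- Compound 3, `C=C[C@@](C)(/C=C/c1ccc(-c2ccccc2)cc1)CCC=C(C)C`. In this assay compound 3 gives > 26000 nM, also a limit.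

Compound 4, `C=C[C@@](C)(/C=C/c1ccc(-c2ccc(F)cc2)cc1)CCC=C(C)C`, has not yet been measured in this assay.

Compound 2 differs from compound 1 by fluoro in place of hydrogen on an aromatic carbon. In this assay this gives a step that the two limits leave unreadable from compound 1 to compound 2. The two cores differ as well: compound 3 differs from compound 1 by phenyl in place of (3,4-difluorophenyl)amino on an aromatic carbon, and in this assay this gives a step that the two limits leave unreadable from compound 1 to compound 3. Neither step can be sized because all three measured values sit at the limit of > 26000 nM in this assay, at which 3 of the 3 values shown sit.

Compound 4 differs from compound 3 by fluoro in place of hydrogen on an aromatic carbon. Going by the values given here, this is the same kind of change as the one from compound 1 to compound 2, but the surroundings differ: in compound 2 the entering fluoro sits ortho to a large group, meta to a fluoro group and para to a fluoro group, whereas in compound 4 it sits para to a large group.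

In this assay the expected step is a step that the limit leaves unreadable from compound 3 to compound 4, which rests on the three measured compounds all standing at the limit of > 26000 nM in this assay, at which 3 of the 3 values shown sit, and on the unreadable earlier step. Compound 4 is therefore expected to give about 40000 nM in this assay, estimated to lie between 15000 nM and 120000 nM, and most likely to be reported only as a limit.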

Compound 4, half-maximal effective concentration: > 26000 nM
Compound 4 was reported as a limit (the forecaster's own chance of this, stated with the estimate: 85%); the middle value does not contradict the limit.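

In this assay compound 4 gives > 26000 nM, which is a limit of the assay and not a number. The steps to compound 4 from compound 3 and from compound 1 therefore cannot be read: the limit of > 26000 nM in this assay, at which 4 of the 4 values shown sit. The compounds shown leave open whether fluoro in place of hydrogen, or any other difference among compounds 1 to 4, changes the read-out at all.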